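Compound 3 to compound 4: adding a hydroxy group

The source may hold more compounds than are shown below. What is called first, only, known or untested is meant among the compounds shown, and "the series" means these compounds.

compound 1 `CCOC(=O)c1cc(-c2cc(OC)c(OC)c(OC)c2)c(-c2ccc(OC)cc2)s1`: 8370 nM
compound 2 `CCOC(=O)c1cc(-c2cc(OC)c(OC)c(OC)c2)c(-c2ccc(OC)c([N+](=O)[O-])c2)s1`: 12700 nM
compound 3 `COc1ccc(-c2sc(C(=O)O)cc2-c2cc(OC)c(OC)c(OC)c2)cc1`: 6770 nM

In a functional assay on HT-1080 cells (Homo sapiens) for antiproliferative activity, read by MTT assay, with a stated time of 72 h (on this read-out lower numbers stand for stronger inhibition and higher numbers for weaker inhibition), the three values lie within the usual scatter of one another, so compound 3 at 6770 nM cannot be ranked against the other two. Compound 4 `COc1ccc(-c2sc(C(=O)O)cc2-c2cc(OC)c(OC)c(OC)c2)cc1O` differs from compound 3 in one place, with hydroxy in place of hydrogen on an aromatic carbon. The 4-methoxyphenyl thus becomes 3-hydroxy-4-methoxyphenyl.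

The closest guide is the swap of nitro for hydrogen on an aromatic carbon of that ring, which gave a 1.5-fold higher number from compound 1 to compound 2 (0.18 log units; within the scatter) as its step. Replacing ethyl with hydrogen elsewhere in the molecule gave a 1.2-fold lower number from compound 1 to compound 3 (0.09 log units; within the scatter) as its step. Among the measured compounds shown here, both stayed within the scatter, but no compound with a hydroxy group has been measured, so the guidance is indirect.

A step within the scatter is therefore expected (a 1.4-fold lower number from compound 3 to compound 4 (0.13 log units; within the scatter)) in this assay for this change. Compound 4 is estimated at 5000 nM as its value, with an expected range from 1500 nM to 15000 nM around it.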

Compound 4, half-maximal inhibitory concentration: 7510 nM
The estimate for compound 4 lay 1.5-fold (0.18 log units) below the measured number; low and high end bracket the measured number.
By their numbers in this assay, from the lowest: compounds 3, 4, 1 and 2 (each within the scatter of the next).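

Adding a hydroxy group ortho to the methoxy group gives a 1.1-fold higher number from compound 3 to compound 4 (0.05 log units; within the scatter) in this assay, the first reading for a hydroxy group at this place on the ring. Nitro at the same place gave a 1.5-fold higher number from compound 1 to compound 2 (0.18 log units; within the scatter) on the ethyl ester, so two different groups have now been added here, and neither step leaves the scatter. Nothing in the data available here explains why the number stays within the scatter after this change.

On these data alone, it remains open whether an amine or a fluorine atom at this place would move the number beyond the scatter. Also open, as far as these compounds go, is whether hydroxy would give a similar step on the ethyl ester of compound 1 as on the carboxylic acid of compound 3.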